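Fluoro in Place of Isopropyl: An Expectation for Compound 4

This account rests on a few compounds, and the source may have more. Where it says the series, first, only, none or still open, it means among the compounds named here.

The measured compounds and their values:
Compound 1, `Clc1ccc(CO/N=C/c2c(-c3ccc4ccccc4c3)nc3occn23)c(Cl)c1`: 1500 nM
Compound 2, `CC(C)c1ccc(-c2nc3sccn3c2/C=N/OCc2ccc(Cl)c(Cl)c2)cc1`: 590 nM
Compound 3, `C(=N/OC1Cc2ccccc2C1)\c1c(-c2ccc3ccccc3c2)nc2occn12`: 980 nM

In an assay on HepG2 cells for agonist activity at nuclear receptor subfamily 1 group I member 3 (Homo sapiens), read by a luciferase reporter, with a stated time of 23 h (a lower number here means that less compound is needed, a higher number that more compound is needed for the effect), compound 2 gives the lowest of the three numbers. Its nearest neighbour is compound 3, whose number lies within the scatter of that of compound 2; the furthest is compound 1, whose number lies beyond the scatter. For the measured compounds named here, the only step between compounds that differ in one place is a 1.5-fold lower number from compound 1 to compound 3 (0.18 log units; within the scatter), which exchanges the group on the oxygen and leaves the aryl ring untouched.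

Compound 4, `Fc1ccc(-c2nc3sccn3c2/C=N/OCc2ccc(Cl)c(Cl)c2)cc1`, differs from compound 2 by fluoro in place of isopropyl on an aromatic carbon. Going by the values given here, no measured step changes that aryl ring, so the one step in hand does not bear on this change, and the pair of compounds 2 and 3 shows only that a change elsewhere in the molecule stays within the scatter. The expectation therefore rests on the value of compound 2 alone, and a step of a 1.5-fold higher number from compound 2 to compound 4 (0.18 log units; within the scatter) is expected, a modest move toward a higher number with a wide range. Compound 4 is estimated at 900 nM in this assay, between 300 nM and 3000 nM.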

Compound 4, half-maximal effective concentration: 670 nM
For compound 4 the middle estimate is 1.3-fold (0.13 log units) above the measured one, and the stated range covers the measured number.
By their numbers in this assay, from the lowest: compounds 2, 4, 3 and 1 (each within the scatter of the next, the first and the last beyond it).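

In this assay, for the compounds shown here, the change from 4-isopropylphenyl to 4-fluorophenyl gives a 1.1-fold higher number from compound 2 to compound 4 (0.06 log units; within the scatter), the first step in this set that touches this aryl ring, at a place para to a large group. The exchange replaces the 3 heavy atoms of isopropyl with the 1 heavy atom of fluoro, and for this pair, the only one shown that differs at this position, the reduction in heavy atoms leaves the number within the scatter. Nothing at hand gives a measured property of either group or accounts for this result at this position.

Going by these compounds alone, it remains open whether an amine, a carboxylic acid or a longer chain such as n-butyl, standing on the same aromatic carbon, would also stay within the scatter of compound 2, since isopropyl and fluoro are the only two groups seen at this place. Going by these compounds, it also remains open whether the same exchange would read alike with 2,3-dihydro-1H-inden-2-yl on the oxygen in place of the dichlorobenzyl group that compound 2 and compound 4 share.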